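The source may report more compounds than this note shows. Statements on the series, on what has been measured and on what is new or still open speak of the compounds shown alone.

Working notes on the series. Of the compounds shown here, two with a shared core have been measured so far: compound 1, `Cc1nc(-c2ccccn2)nc(N(C)C)c1Cl`, and compound 2, `Cc1nc(-c2ccccn2)nc(NCCCc2ccccc2)c1Cl`. For the measured compounds named here, in an ADME assay on L6 cells (Rattus norvegicus) for cytotoxicity (a higher number here means a weaker inhibitor, a lower number a stronger inhibitor), compound 1 gives 115000 nM and compound 2 gives 73500 nM, so compound 2 stands within the scatter of the only other number available.

Compound 3, `Cc1nc(-c2ccccn2)nc(NCCC2CCCCC2)c1Cl`, has not yet been measured in this assay. It differs from compound 2 by cyclohexyl in place of benzyl on a saturated chain carbon, two bonds along the chain from a nitrogen on an aromatic ring. Cut one bond further out, the same difference reads phenethyl to cyclohexylmethyl.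

Going by the values given here, no measured pair shows this change, so the data offer no direct precedent. The expectation therefore starts from compound 2 at 73500 nM, with no clear direction and no shift beyond the scatter. The expected change is small, with a 1.1-fold lower number from compound 2 to compound 3 (0.02 log units; within the scatter) as the estimated step. For compound 3 the estimated value is 70000 nM, with an expected range of 30000 nM to 140000 nM.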

Compound 3, half-maximal inhibitory concentration: 49500 nM
Beside the measured number, compound 3's estimate is 1.4-fold (0.15 log units) above it, within the range that was stated.
By their numbers in this assay, from the lowest: compounds 3, 2 and 1 (each within the scatter of the next, the first and the last beyond it).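

In this assay, putting cyclohexyl in place of benzyl on a saturated chain carbon, two bonds along the chain from a nitrogen on an aromatic ring, gives a 1.5-fold lower number from compound 2 to compound 3 (0.17 log units; within the scatter). For the compounds shown here, this is the first step read at this position: a six-membered aromatic ring of carbon only gives way to a six-membered non-aromatic ring of carbon only, with no shift that stands clear of the scatter, something compound 1 and compound 2 alone could not show. No measurement at hand speaks to what lies behind this result.

Open, as far as these compounds go, is whether a terminal amine or a carboxylic acid at the same place, or a longer chain carrying the cyclohexyl, would also stay within the scatter of compound 2 and compound 3. Also open, from the compounds shown here alone, is whether the exchange of benzyl for cyclohexyl would read the same on a core other than the shared one, as this single pair gives no second instance of the change.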